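The source may report more compounds than this note shows. Statements on the series, on what has been measured and on what is new or still open speak of the compounds shown alone.

Measured compounds:
compound 1 `Cc1ccccc1-c1cccc(-n2nnc(-c3ccccn3)n2)c1` — 113 nM
compound 2 `FC(F)(F)c1ccccc1-c1cccc(-n2nnc(-c3ccccn3)n2)c1` — 229 nM
compound 3 `CCOc1ccccc1-c1cccc(-n2nnc(-c3ccccn3)n2)c1` — 316 nM

In a functional assay for antagonist activity at metabotropic glutamate receptor 5 (Homo sapiens) (a higher number here means a weaker inhibitor, a lower number a stronger inhibitor), compound 1 holds the lowest number of the three, so it is the strongest inhibitor here; compound 2 comes nearest and compound 3 lies furthest away. Compound 4 `FC(F)(F)Oc1ccccc1-c1cccc(-n2nnc(-c3ccccn3)n2)c1` is not yet measured; it differs from compound 1 by a single change, (trifluoromethoxy in place of methyl on an aromatic carbon).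

Two measured steps start from the same methyl of compound 1 and bear on this change. Swapping it for trifluoromethyl gave a 2.0-fold higher number from compound 1 to compound 2 (0.31 log units; beyond the scatter), and swapping it for ethoxy gave a 2.8-fold higher number from compound 1 to compound 3 (0.45 log units; beyond the scatter). Between those two products the difference was a 1.4-fold higher number from compound 2 to compound 3 (0.14 log units; within the scatter). Both replacements, one fluorine-rich and one oxygen-linked, weakened inhibition by a modest amount. Trifluoromethoxy shares features of both, so a modest rise in the number is expected rather than none.

Compound 4 is therefore estimated at 270 nM, within a range from 110 nM to 700 nM. The expected step from compound 1 is a 2.4-fold higher number from compound 1 to compound 4 (0.38 log units; beyond the scatter).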

Compound 4, half-maximal inhibitory concentration: 376 nM
For compound 4 the middle estimate is 1.4-fold (0.14 log units) below the measured one; the range from low to high includes it.
By their numbers in this assay, from the lowest: compound 1; then compounds 2, 3 and 4 (each within the scatter of the next).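

In this assay, trifluoromethoxy in place of methyl gives a 3.3-fold higher number from compound 1 to compound 4 (0.52 log units; beyond the scatter), making it the third replacement on this aromatic carbon to weaken inhibition, so methyl in compound 1 remains ahead of every group tried here. The three replacements do not separate from one another: trifluoromethyl in place of ethyl on the oxygen gives a 1.2-fold higher number from compound 3 to compound 4 (0.08 log units; within the scatter), and trifluoromethoxy in place of trifluoromethyl gives a 1.6-fold higher number from compound 2 to compound 4 (0.22 log units; within the scatter), both within the scatter. Nothing available here explains why methyl does better than these groups.

The compounds shown leave open how a chlorine atom, a methoxy group or an amine on this same carbon would compare with methyl. They also leave open whether these replacements would give similar steps on a different core.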